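Phenyl in Place of Amino: Expecting Another Limit

The source may report more compounds than this note shows. Statements on the series, on what has been measured and on what is new or still open speak of the compounds shown alone.

Compound 1, `Cc1cc(C)n2nc(SCc3nnc(SCc4coc5ccccc5c4=O)n3-c3ccccc3)nc2n1`, gives a limit of > 25000 nM.
Compound 2, `Cc1cc(C)n2nc(SCc3nnc(SCc4cc(=O)c5ccccc5o4)n3N)nc2n1`, gives a limit of > 25000 nM.
Compound 3, `Cc1cc(O)cc2oc(=O)cc(CSc3nc4ccccc4o3)c12`, gives a limit of > 25000 nM.

In a functional assay on HeLa cells (Homo sapiens) for cytotoxicity, read by MTT assay, with a stated time of 72 h (on this read-out higher numbers stand for weaker inhibition and lower numbers for stronger inhibition), none of the three measured compounds yields a number: all three sit at the assay limit, (the limit of > 25000 nM in this assay, at which 3 of the 3 values shown sit). Among the compounds with values here, compound 2 therefore stands exactly where compound 1 and compound 3 stand, and no step between any pair of measured compounds can be set down; the values show only that nothing separates them within what the assay reports.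

Compound 4, `Cc1cc(C)n2nc(SCc3nnc(SCc4cc(=O)c5ccccc5o4)n3-c3ccccc3)nc2n1`, departs from compound 2 by phenyl in place of amino on an aromatic nitrogen. Compound 1 also bears a phenyl on an aromatic nitrogen and sits at the same limit as compound 2, so the change from amino to phenyl gives no sign of moving a compound off the limit.

Accordingly no step beyond the scatter is expected from compound 2 to compound 4 in this assay, and the step that the limit leaves unreadable from compound 2 to compound 4 is expected to be flat. Compound 4 is expected to give about 30000 nM in this assay, somewhere between 12000 nM and 80000 nM, most probably reported again as a limit rather than a number.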

Compound 4, half-maximal inhibitory concentration: > 25000 nM
Compound 4 ended at the assay's limit; the forecaster's own chance of this, stated with the estimate: 85%; the middle value lies beyond the limit too.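

Within the data shown here, compound 4 stays at a limit in this assay, as do compound 1 and compound 2, so no step from either of them to compound 4 can be read: the limit of > 25000 nM in this assay, at which 4 of the 4 values shown sit. The compounds shown leave open whether phenyl in place of amino on an aromatic nitrogen changes cytotoxicity at all, since none of them gives a number.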